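A few compounds are considered here, and "the series" means these few. Any claim that something is new, unique, unknown or untested is made for them only; others in the source may bear on it.

Compound 1 `COc1ccccc1N1C(=O)C(C)SC1c1cccc(C(=O)NCCCCc2ccccc2)c1`: 94%
Compound 2 `COc1ccc(OC)c(N2C(=O)CSC2c2cccc(C(=O)NCCCCc3ccccc3)c2)c1`: 92%
Compound 3 `CCOc1ccccc1N1C(=O)C(C)SC1c1cccc(C(=O)NCCCCc2ccccc2)c1`: 92%

In a functional assay on MG-63 cells (Homo sapiens) for inhibition, read by CCK-8 assay, with a stated time of 72 h, tested at 1 uM (a lower number here means less inhibition, a higher number more inhibition at the concentration tested (going by the name of the read-out)), compound 2 gives 92%, which is level with compound 3 at the digits shown, and the two stand together as the lowest of the three numbers. Its furthest neighbour is compound 1, which in this assay gives 94%, a gap that lies within the scatter of this kind of measurement, so the three compounds cannot be told apart.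

Compound 4 `COc1cc(F)ccc1N1C(=O)CSC1c1cccc(C(=O)NCCCCc2ccccc2)c1` differs from compound 2 in this way: 4-fluoro-2-methoxyphenyl in place of 2,5-dimethoxyphenyl on an amide-type nitrogen in a ring. Among the measured compounds shown here, the only measured single-point step, a number 2 percentage points lower from compound 1 to compound 3 (within the scatter), concerns a change on the chain carbon bound to the ring oxygen and not the pattern of groups on the aryl ring, so it does not bear directly on this change. What the data do show is that three different aryl groups on the ring nitrogen all give high inhibition in this assay. The step of a number 2 percentage points lower from compound 2 to compound 4 (within the scatter) is therefore expected to be small, with no direction beyond the scatter. Compound 4 is estimated at 90%, in the range 78% to 97%.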

Compound 4, a percentage reported as inhibition, at one concentration (the size of the read-out at that concentration, not a potency): 92%
Compound 4: the middle estimate sits 2 percentage points below what was measured, and the stated range covers the measured number.
By their numbers in this assay, from the lowest: compounds 2, 3, 4 and 1 (each within the scatter of the next).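

In this assay, putting 4-fluoro-2-methoxyphenyl in place of 2,5-dimethoxyphenyl on the amide-type nitrogen in the ring gives no change at the digits printed from compound 2 to compound 4 (within the scatter). This is the first step shown at this position, and it indicates that a methoxy group can be lost and a fluorine gained on the aryl ring with no change in inhibition that can be read at the one concentration tested. Nothing measured here accounts for a step of this size.

Going by these compounds, whether a carboxylic acid or an amine on the aryl ring, or a cyclohexyl ring in place of the aryl group, would keep this level of inhibition remains open. Also open, on these data alone, is whether compound 2 and compound 4 would separate at lower concentrations, since a single-concentration percentage is not a potency.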